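The source may report more compounds than this note shows. Statements on the series, on what has been measured and on what is new or still open speak of the compounds shown alone.

In an in vitro ADME assay on microsomes (Homo sapiens) for metabolic stability (a lower number here means that the compound disappears faster, a higher number that the compound lasts longer), three compounds built on a shared core have been measured so far. Compound 1 `CCc1nc(-c2ccc(OC(F)(F)F)cc2OC)c(CC)nc1NC(CC)CC` gives 0.217 h, compound 2 `CCc1nc(-c2ccc(OC)cc2OC(F)(F)F)c(CC)nc1NC(CC)CC` gives 0.267 h, and compound 3 `CCc1nc(-c2ccc(Cl)cc2Cl)c(CC)nc1NC(C1CC1)C1CC1` gives 0.183 h. These numbers lie within the usual scatter of repeated measurements, so compound 3 stands level with the other two.

Compound 4 `CCCN(CC1CC1)c1nc(CC)c(-c2ccc(Cl)cc2Cl)nc1CC` keeps the 2,4-dichlorophenyl group of compound 3 and alters only the amino group on the core: (cyclopropylmethyl)(propyl)amino in place of (dicyclopropylmethyl)amino on an aromatic carbon. Among the compounds with values here, no two measured compounds differ in just one place, so no measured step shows directly what this swap does. Within the data shown here, the only guide is how closely the three numbers sit despite their different groups, with compound 2 at 0.267 h and compound 3 at 0.183 h. On that thin basis, no change beyond the scatter is expected, and the estimated step is a 1.1-fold lower number from compound 3 to compound 4 (0.03 log units; within the scatter). The half-life expected for compound 4 is 0.17 h, within an estimated range of 0.08 h to 0.35 h.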

Compound 4, half-life: 0.2 h
Compound 4: middle estimate off by 1.2-fold (0.07 log units), on the low side, and the stated range covers the measured number.
By their numbers in this assay, from the lowest: compounds 3, 4, 1 and 2 (each within the scatter of the next).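

Within the data shown here, this is the first pair in the set that differs in one place only, so the amino group on the aromatic carbon can now be read directly: in this assay, (cyclopropylmethyl)(propyl)amino in place of (dicyclopropylmethyl)amino gives a 1.1-fold higher number from compound 3 to compound 4 (0.04 log units; within the scatter) for this exchange. The entering group has no hydrogen-bond donor and one three-membered ring fewer, yet in this single pair these differences come with no change beyond the scatter. Nothing measured here points to a cause for this.

Going by these compounds, whether an amino group carrying a longer chain or a carboxylic acid would move the half-life at this position remains open. So does whether the same exchange would behave alike with the substituted phenyl groups of compound 1 and compound 2.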